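This account rests on a few compounds, and the source may have more. Where it says the series, first, only, none or still open, it means among the compounds named here.

Measured compounds: compound 1 `CCN(CC)CCCNc1nc(-c2ccc(NC(=O)Nc3ccccc3Cl)cc2)nc2c(Cl)c(Cl)sc12` gives 970 nM in a functional assay on MDA-MB-231 cells (Homo sapiens) for cytotoxicity, read by MTT assay, with a stated time of 72 h; on this read-out higher numbers stand for weaker inhibition and lower numbers for stronger inhibition; compound 2 `CCN(CC)CCCNc1nc(-c2ccc(NC(=O)Nc3ccc(Cl)cc3Cl)cc2)nc2c(Cl)c(Cl)sc12` gives 3940 nM; compound 3 `CCN(CC)CCCNc1nc(-c2ccc(NC(=O)Nc3ccc(C)cc3)cc2)nc2c(Cl)c(Cl)sc12` gives 3040 nM.

Compound 3 stands second highest of the three numbers. Its nearest neighbour is compound 2, the step being a 1.3-fold lower number from compound 2 to compound 3 (0.11 log units; within the scatter), within the scatter; the step of a 3.1-fold higher number from compound 1 to compound 3 (0.50 log units; beyond the scatter) sets compound 1 apart as the lower number. Compound 4 `CCN(CC)CCNc1nc(-c2ccc(NC(=O)Nc3ccc(C)cc3)cc2)nc2c(Cl)c(Cl)sc12` differs from compound 3 by diethylamino in place of (diethylamino)methyl on a saturated chain carbon, two bonds along the chain from a nitrogen on an aromatic ring. Among the measured compounds shown here, none of the measured steps bears on this chain: both a 4.1-fold higher number from compound 1 to compound 2 (0.61 log units; beyond the scatter) and a 3.1-fold higher number from compound 1 to compound 3 (0.50 log units; beyond the scatter) concern the aryl group on the urea, and the chain is unchanged across compounds 1 to 3. For the measured compounds named here, with no precedent for the change, a step within the scatter is expected, a 1.1-fold higher number from compound 3 to compound 4 (0.04 log units; within the scatter). Compound 4 is therefore estimated at 3300 nM, with a range of 1100 nM to 10000 nM.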

Compound 4, half-maximal inhibitory concentration: 2010 nM
For compound 4 the middle estimate is 1.6-fold (0.22 log units) above the measured one, and the stated range covers the measured number.
By their numbers in this assay, from the lowest: compound 1; then compounds 4, 3 and 2 (each within the scatter of the next).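

In this assay, the change from (3-(diethylamino)propyl)amino to (2-(diethylamino)ethyl)amino gives a 1.5-fold lower number from compound 3 to compound 4 (0.18 log units; within the scatter) and is the first change shown on this chain rather than on the aryl group of the urea. With 4-methylphenyl on the urea, the 2-(diethylamino)ethyl chain therefore holds the number within the scatter of the 3-(diethylamino)propyl chain. No measured evidence accounts for this result.

On these data alone, it remains open whether the same holds with the 2-chlorophenyl group of compound 1. Also open, as far as these compounds go, is what a longer chain, or a morpholine in place of diethylamino, would do.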